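Amino in place of hydrogen on the core of compound 1

The source may hold more compounds than are shown below. What is called first, only, known or untested is meant among the compounds shown, and "the series" means these compounds.

Compound 1 `C[C@H](Nc1ncnc2[nH]cnc12)c1nn(-c2cccnc2)c2cc(F)ccc12` stands highest of the three measured numbers. In a functional assay on Hep 3B2 cells (Homo sapiens) for inhibition, read by sulforhodamine B assay, with a stated time of 72 h, tested at 10 uM (a lower number here means less inhibition, a higher number more inhibition at the concentration tested (going by the name of the read-out)), compound 1 gives 20%. Compound 2 `C[C@H](Nc1ncnc2[nH]cnc12)c1nn(-c2ccncc2)c2cc(F)ccc12` gives 5% in this assay, and compound 3 `CC[C@H](Nc1ncnc2[nH]cnc12)c1nn(-c2cccnc2)c2cc(F)ccc12` gives 4%. The two measured steps, a number 15 percentage points lower from compound 1 to compound 2 (beyond the scatter) and a number 16 percentage points lower from compound 1 to compound 3 (beyond the scatter), are both modest drops from compound 1 and both concern positions on the aromatic nitrogen substituent or the saturated chain, not the shared core.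

Compound 4 `C[C@H](Nc1nc(N)nc2[nH]cnc12)c1nn(-c2cccnc2)c2cc(F)ccc12` differs from compound 1 by amino in place of hydrogen on an aromatic carbon. Neither measured step touches an aromatic carbon of the core between two ring nitrogen atoms, so no measured step bears directly on this change; the two steps shown only indicate that single changes elsewhere in compound 1 have so far lowered the number in this assay. Among the compounds with values here, with no direct precedent, the expected step is no change at the digits printed from compound 1 to compound 4 (within the scatter), which is none beyond the scatter, with a wide range. Compound 4 is therefore estimated to give 20% in this assay, expected between 0% and 45%.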

Compound 4, a percentage reported as inhibition, at one concentration (the size of the read-out at that concentration, not a potency): 14%
Compound 4: middle estimate off by 6 percentage points, on the high side; measured number inside the range.
By their numbers in this assay, from the lowest: compounds 3, 2, 4 and 1 (each within the scatter of the next, the first and the last beyond it).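

Amino in place of hydrogen on the aromatic carbon between two ring nitrogen atoms gives a number 6 percentage points lower from compound 1 to compound 4 (within the scatter) in this assay and so, unlike the two earlier single changes on compound 1, does not shift the number beyond the scatter. This carbon of the shared core is thus the first position shown to take a change without a readable loss of inhibition at the concentration tested. No measurement is at hand that would explain this result.

As far as these compounds go, whether larger or different groups on this carbon, such as a dimethylamino or a hydroxyl, would also leave the number within the scatter remains open. From the compounds shown here alone, it is also open whether amino at this carbon would act the same way alongside the pyridin-4-yl of compound 2 or the longer chain of compound 3.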